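A few compounds are considered here, and "the series" means these few. Any claim that something is new, unique, unknown or untested is made for them only; others in the source may bear on it.

Measured so far:
Compound 1 `O=C(O)CCC/C=C\C[C@@H]1[C@@H](NS(=O)(=O)c2ccc(F)cc2)CC[C@@H]1O` gives 640 nM
Compound 2 `O=C(O)CCC/C=C\C[C@@H]1[C@H](O)CC[C@H]1NS(=O)(=O)c1ccc(Cl)cc1` gives 2200 nM

In a functional assay (plasma) for inhibition, with Homo sapiens as the target (on this read-out lower numbers stand for stronger inhibition and higher numbers for weaker inhibition), compound 2 stands at the higher end of the two numbers with 2200 nM as its value, while compound 1 with 640 nM lies lower by a gap beyond the usual scatter. Compound 2 is thus the weaker inhibitor of the pair.

Compound 3 `O=C(O)CCC/C=C\C[C@@H]1[C@@H](NS(=O)(=O)c2ccc(Cl)cc2)CC[C@@H]1O` has yet to be measured. It keeps the atoms and bonds of compound 2 and differs only in configuration as drawn (the two compounds have the same atoms and bonds and differ only in configuration as drawn: 3 of 4 stereo elements differ; a stereocentre at a saturated ring carbon is drawn S in compound 2 and R in compound 3; a stereocentre at a saturated ring carbon is drawn R in compound 2 and S in compound 3; a stereocentre at a saturated ring carbon is drawn R in compound 2 and S in compound 3). Going by the values given here, no measured pair shows directly what such a change does in this assay here, so its size remains uncertain and the range stays wide. The only guide is the gap between the two numbers: compound 2 at 2200 nM sits at the top, and compound 1 at 640 nM shows that a clearly lower number occurs among these compounds. A move toward stronger inhibition, beyond the scatter, is expected, estimated as a 4.9-fold lower number from compound 2 to compound 3 (0.69 log units; beyond the scatter) in size. The estimated value for compound 3 is 450 nM within a range of 120 nM to 1700 nM (expected, not yet measured).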

Compound 3, half-maximal inhibitory concentration: 190 nM
Compound 3: middle estimate off by 2.4-fold (0.37 log units), on the high side, and the stated range covers the measured number.
By their numbers in this assay, from the lowest: compound 3; then compound 1; then compound 2.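

In this assay, the drawn configuration alone carries a large step (a 12-fold lower number from compound 2 to compound 3 (1.06 log units; beyond the scatter)), a change in which no atom or bond is replaced. The step can be assigned to configuration and to nothing else because of a single structural fact: the fact that compounds 2 and 3 differ only in the configuration as drawn. The halogen has its own, smaller effect when the configuration is held fixed, with chloro in place of fluoro on an aromatic carbon giving a modest step beyond the scatter (a 3.4-fold lower number from compound 1 to compound 3 (0.53 log units; beyond the scatter)), whereas the earlier pair differed in both the halogen and the configuration and could separate neither contribution.

Three stereocentres change together between compound 2 and compound 3, so the compounds shown do not tell whether one of them accounts for most of the step or all three contribute. From the compounds shown here alone, the halogen step is also read in only one configuration, and it remains open how a bromo or methoxy group on the same aromatic carbon would compare, or whether a methyl ester could take the place of the carboxylic acid.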